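The compounds below may be only part of what the source reports. "The series", "measured", "known", "first", "only" and "open" are said of these compounds alone.

Compound 3 `COc1cc(NC(C)CCCNC(=O)NC2CCCC2)c2ncccc2c1` carries a cyclopentylcarbamoyl group on the shared core. Among the measured compounds shown here, in a functional assay on SW-620 cells (Homo sapiens), read by MTT assay, with a stated time of 72 h (a lower number here means a stronger inhibitor, a higher number a weaker inhibitor), compound 3 gives 19000 nM, one of only two numbers available. Compound 2 `COc1cc(NC(C)CCCNC(=O)N(C2CCCCC2)C2CCCCC2)c2ncccc2c1` gives 15000 nM, and its gap to compound 3 lies within the usual scatter. Compound 1 `CCN(CC)C(=O)NCCCC(C)Nc1cc(OC)cc2cccnc12` gives only a limit of the assay, > 100000 nM. For the measured compounds named here, the single measured step, an at least 5.2-fold lower number from compound 1 to compound 3 (0.72 log units; beyond the scatter), concerns what sits on the carbonyl carbon rather than ring size, so it bears only loosely on the change to compound 4 `COc1cc(NC(C)CCCNC(=O)NC2CCCCC2)c2ncccc2c1`, (cyclohexyl in place of cyclopentyl on an amide-type nitrogen). Since compound 2, with two cyclohexyl groups, sits within the scatter of compound 3, no step beyond the scatter is expected, a 1.3-fold lower number from compound 3 to compound 4 (0.10 log units; within the scatter). Compound 4 is estimated at 15000 nM, from 6000 nM to 40000 nM.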

Compound 4, half-maximal inhibitory concentration: 49000 nM
For compound 4 the middle estimate is 3.3-fold (0.51 log units) below the measured one; measured number outside the range, above it.
By their numbers in this assay, from the lowest: compounds 2 and 3 (each within the scatter of the next); then compound 4. At a limit, above all of these: compound 1.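

Cyclohexyl in place of cyclopentyl on an amide-type nitrogen matters in this assay: this change gives a 2.6-fold higher number from compound 3 to compound 4 (0.41 log units; beyond the scatter), a modest step. Hydrogen in place of one cyclohexyl on the same nitrogen gives a 3.3-fold higher number from compound 2 to compound 4 (0.51 log units; beyond the scatter), so a larger group here does not always mean a higher number. Compound 1 stands only at a limit: the limit of > 100000 nM in this assay, at which 1 of the 4 values shown sits. Cyclohexylamino in place of diethylamino on a carbonyl carbon gives an at least 2.0-fold lower number from compound 1 to compound 4 (0.30 log units; that floor lies within the scatter), so this step can be read only as a floor.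

The compounds shown leave open how a cycloheptyl or phenyl group on this nitrogen would compare.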